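Adding a Methylsulfanyl Group to Compound 3

The source may report more compounds than this note shows. Statements on the series, on what has been measured and on what is new or still open speak of the compounds shown alone.

Compound 1 `COc1ccc(CNc2nc([Se]C)nc3ccccc23)cc1`: > 100000 nM in a functional assay on CCRF-CEM cells (Homo sapiens) for cytotoxicity, read by MTT assay, with a stated time of 72 h (a lower number here means that less compound is tolerated, a higher number that more compound is tolerated), which is a limit of the assay.
Compound 2 `CSc1ccc(CNc2nc([SeH])nc3ccccc23)cc1`: > 100000 nM, also a limit.
Compound 3 `C[Se]c1nc(NCc2ccccc2)c2ccccc2n1`: 83500 nM.

Within the data shown here, compound 3 therefore holds the only true number among the three measured compounds; the other two sit at the limit of > 100000 nM in this assay, at which 2 of the 3 values shown sit. Compound 4 `CSc1ccc(CNc2nc([Se]C)nc3ccccc23)cc1` differs from compound 3 by methylsulfanyl in place of hydrogen on an aromatic carbon. Among the measured compounds shown here, the one measured step, an at least 1.1-fold lower number from compound 1 to compound 3 (0.07 log units; that floor lies within the scatter), swapped a methoxy for hydrogen and stayed within the scatter, with compound 1 reported only as a limit. Adding a group again is expected to move compound 4 back toward that limit, so compound 4 is estimated at about 110000 nM, between 50000 nM and 250000 nM. The step of a 1.3-fold higher number from compound 3 to compound 4 (0.12 log units; within the scatter) is expected to be small, and a bare limit is a real possibility.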

Compound 4, concentration lethal to 50% of the cells: > 100000 nM
Compound 4: a limit, no number; the forecaster's own chance of this, stated with the estimate: 55%; the middle value lies beyond the limit too.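

Methylsulfanyl on an aromatic carbon para to a large group gives, in this assay, an at least 1.1-fold higher number from compound 3 to compound 4 (0.07 log units; that floor lies within the scatter). So a second group at this place, after methoxy, ends at a limit and not at a number, and the true size of the step stays unknown: the limit of > 100000 nM in this assay, at which 3 of the 4 values shown sit. The steps to compound 4 from compound 1 and from compound 2 cannot be read, since both ends of each are limits.

Open, on these data alone, is whether a group such as an amine or a carboxylic acid at this position would give a true number in this assay. Also open, as far as these compounds go, is what a longer chain on the selenium would do.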